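Swapping a Triazole for an Amide Side Chain

This account rests on a few compounds, and the source may have more. Where it says the series, first, only, none or still open, it means among the compounds named here.

Compound 2 `CC(C)C(c1nnc[nH]1)c1ccc(-c2ccc3cccc(F)c3c2)[nH]c1=O` has been tested in a functional assay on CHO cells for antagonist activity at prostaglandin E2 receptor EP3 subtype (Homo sapiens), read by cAMP accumulation (on this read-out higher numbers stand for weaker inhibition and lower numbers for stronger inhibition), where compound 2 gives 21 nM. Within the data shown here, compound 1 `CCC(CC)(c1nnc[nH]1)c1ccc(-c2ccc3cc(F)cc(F)c3c2)[nH]c1=O` shares the same core, and in this assay compound 1 gives 350 nM, so compound 2 stands as the lower of the two numbers measured so far, with a gap between them that lies well beyond the usual scatter of repeated measurements. Compound 3 `CC(C)NC(=O)CC(c1ccc(-c2ccc3cccc(F)c3c2)[nH]c1=O)C(C)C` has not yet been measured. It differs from compound 2 in a single place: (isopropylcarbamoyl)methyl in place of 4H-1,2,4-triazol-3-yl on a saturated chain carbon bound to an aromatic carbon and a saturated chain carbon. Among the measured compounds shown here, no step between two measured compounds covers this kind of change, so there is no direct precedent to lean on. The step of a 12-fold higher number from compound 2 to compound 3 (1.08 log units; beyond the scatter) is expected to weaken inhibition by an amount beyond the scatter. Compound 3 is therefore estimated at 250 nM, with a plausible range from 50 nM to 2000 nM.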

Compound 3, half-maximal inhibitory concentration: 15 nM
Compound 3: the middle estimate sits 17-fold (1.22 log units) above what was measured; the whole stated range lies above it.
By their numbers in this assay, from the lowest: compounds 3 and 2 (each within the scatter of the next); then compound 1.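

On a saturated chain carbon bound to an aromatic carbon and a saturated chain carbon, the 4H-1,2,4-triazol-3-yl ring turns out not to be needed for activity in this assay: replacing it with (isopropylcarbamoyl)methyl gives a 1.4-fold lower number from compound 2 to compound 3 (0.15 log units; within the scatter). This position therefore accepts an open chain with no ring as well as a five-membered aromatic ring, even though the new group has 7 heavy atoms against 5. Both groups carry 1 hydrogen-bond donor, but no measurement here tells whether that shared feature matters for the result.

On these data alone, it remains open which part of the new side chain counts, the amide hydrogen, the carbonyl or the isopropyl group. A carboxylic acid or a methyl ester in place of the isopropylcarbamoyl part would bear on that question.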